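This account rests on a few compounds, and the source may have more. Where it says the series, first, only, none or still open, it means among the compounds named here.

Compound 1 `CCOC(=O)c1c(C)coc1-c1ccc2c(CC)cccc2c1OC`: 2.2 ug/mL
Compound 2 `CCc1cccc2c(OC)c(-c3occ(C)c3C(=S)OC)ccc12`: 5.7 ug/mL
Compound 3 `CCc1cccc2c(OC(C)=O)c(-c3occ(C)c3COC(C)=O)ccc12`: a limit, > 10 ug/mL

In a functional assay on DU-145 cells (Homo sapiens) for cytotoxicity, read by MTT assay, with a stated time of 72 h (a higher number here means that more compound is needed for the effect, a lower number that less compound is needed), compound 1 gives 2.2 ug/mL and compound 2 gives 5.7 ug/mL, a step of a 2.6-fold higher number from compound 1 to compound 2 (0.41 log units; beyond the scatter) that sits on an aromatic carbon. Compound 3 reaches only a limit in this assay, > 10 ug/mL, and so stands at the limit of > 10 ug/mL in this assay, at which 1 of the 3 values shown sits. Compound 4 `CCOc1c(-c2occ(C)c2COC(C)=O)ccc2c(CC)cccc12` differs from compound 3 by ethyl in place of acetyl on an oxygen on an aromatic ring. Among the measured compounds shown here, no measured step touches that oxygen; the one measured step, from compound 1 to compound 2, lies elsewhere, so it offers no guide to direction or size here. The estimate for compound 4 is therefore a step of an at least 1.2-fold lower number from compound 3 to compound 4 (0.09 log units; that floor lies within the scatter). Compound 4 is expected at 8 ug/mL, with a range from 3 ug/mL to 20 ug/mL, and a fair chance that this assay again reports only a limit.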

Compound 4, concentration for half-maximal effect: > 10 ug/mL
Compound 4: only a limit was reported; the forecaster's own chance of this, stated with the estimate: 40%; middle value at least 1.2-fold (0.09 log units) away from the limit.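

Compound 3 and compound 4 each reach only a limit in this assay, so no step between them can be read: the limit of > 10 ug/mL in this assay, at which 2 of the 4 values shown sit.

The compounds shown leave open whether ethyl in place of acetyl on that oxygen changes the number in this assay at all.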